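The compounds below may be only part of what the source reports. "The series", "measured", "known", "first", "only" and "open" are said of these compounds alone.

Compound 2 `N#Cc1ccc(NC(=O)Nc2ccccc2Br)c(O)c1` stands highest of the two numbers in an assay for inhibition of C-X-C chemokine receptor type 1 (Homo sapiens), read by radioligand binding (a lower number here means a stronger inhibitor, a higher number a weaker inhibitor), where compound 2 gives 15100 nM; nearest is compound 1 `N#Cc1ccc(NC(=O)Nc2ccccc2Br)c(O)c1Cl`, which in this assay gives 4200 nM. For the measured compounds named here, the one measured step, a 3.6-fold higher number from compound 1 to compound 2 (0.56 log units; beyond the scatter), hydrogen in place of chloro on an aromatic carbon, bears directly on compound 3 `N#Cc1ccc(NC(=O)Nc2ccccc2Br)c(O)c1Br`, which differs from compound 2 by bromo in place of hydrogen on an aromatic carbon, ortho to a cyano group, ortho to a hydroxy group, meta to a large group. Given a 3.6-fold higher number from compound 1 to compound 2 (0.56 log units; beyond the scatter), a halogen re-entering at that carbon is expected to give a lower number of about that size, so the expected step is a 3.8-fold lower number from compound 2 to compound 3 (0.58 log units; beyond the scatter). Compound 3 is estimated at 4000 nM, range 1500 nM to 10000 nM.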

Compound 3, half-maximal inhibitory concentration: 2600 nM
Estimate against measurement, compound 3: 1.5-fold (0.19 log units) above, within the range that was stated.
By their numbers in this assay, from the lowest: compounds 3 and 1 (each within the scatter of the next); then compound 2.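

In this assay, bromo on this carbon, ortho to a cyano group and ortho to a hydroxy group, gives a 5.8-fold lower number from compound 2 to compound 3 (0.76 log units; beyond the scatter), so the gain seen with chloro is not confined to that one halogen. The exchange of the two halogens gives a 1.6-fold lower number from compound 1 to compound 3 (0.21 log units; within the scatter), and at this carbon they cannot be told apart. Nothing available explains this result.

Open, as far as these compounds go, is whether a fluoro, a methyl or a methoxy at this carbon reads like the two halogens or like hydrogen. Also open, from the compounds shown here alone, is whether an amine there would be tolerated.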